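The source may hold more compounds than are shown below. What is called first, only, known or untested is meant among the compounds shown, and "the series" means these compounds.

Compound 1 `CCCCNC(=O)NS(=O)(=O)c1ccc(-n2nc(-c3ccc(C)cc3)ccc2=O)cc1` is the starting point of this small set. In a functional assay on the whole organism (blood, strain Wistar albino) for inhibition, with Rattus norvegicus as the target, read by colorimetric assay, with stated times of 15 min and 90 min, at a dose of 20 mg/kg by the oral route (a higher number here means more inhibition at the dose given (going by the name of the read-out), a lower number less inhibition), compound 1 gives 86.6%. Compound 2 `Cc1ccc(-c2ccc(=O)n(-c3ccc(S(=O)(=O)NC(=O)NC4CCCCC4)cc3)n2)cc1` differs from it by cyclohexyl in place of butyl on an amide-type nitrogen, and in this assay compound 2 gives 79.9%, so that a number 6.7 percentage points lower from compound 1 to compound 2 (within the scatter). Compound 3 `CCCCNC(=O)NS(=O)(=O)c1ccc(-n2nc(-c3ccc(Cl)cc3)ccc2=O)cc1` keeps the butyl group of compound 1 but carries chloro in place of methyl on an aromatic carbon; in this assay compound 3 gives 66%, and a number 20.6 percentage points lower from compound 1 to compound 3 (beyond the scatter).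

Compound 4 `O=C(NC1CCCCC1)NS(=O)(=O)c1ccc(-n2nc(-c3ccc(Cl)cc3)ccc2=O)cc1` has not yet been measured. It is built on the core of compound 3, and the two cores differ in the way already described for compound 3 against compound 1. From compound 3 to compound 4 the change is cyclohexyl in place of butyl on an amide-type nitrogen, the same change as from compound 1 to compound 2, at a place described in identical words. Because a number 6.7 percentage points lower from compound 1 to compound 2 (within the scatter), the expectation is that a number 6 percentage points lower from compound 3 to compound 4 (within the scatter). On that basis compound 4 is expected to give about 60% in this assay, estimated to fall between 45% and 75%.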

Compound 4, a percentage reported as inhibition, in the whole organism at one dose (the size of the read-out at that dose, not a potency): 59%
Beside the measured number, compound 4's estimate is 1 percentage points above it, and the stated range covers the measured number.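

In this assay, putting cyclohexyl in place of butyl on the amide-type nitrogen of the chloro compound gives a number 7 percentage points lower from compound 3 to compound 4 (within the scatter), and this agrees with the same swap on the methyl compounds: the same change on two cores in this assay, a number 6.7 percentage points lower (within the scatter) from compound 1 to compound 2 and a number 7 percentage points lower (within the scatter) from compound 3 to compound 4, 0.3 percentage points apart, within the scatter of two such steps. Putting chloro in place of methyl with cyclohexyl present gives a number 20.9 percentage points lower from compound 2 to compound 4 (beyond the scatter), and this also agrees with the earlier step: the same change on two cores in this assay, a number 20.6 percentage points lower (beyond the scatter) from compound 1 to compound 3 and a number 20.9 percentage points lower (beyond the scatter) from compound 2 to compound 4, 0.3 percentage points apart, within the scatter of two such steps. In these four compounds, each change therefore gives a similar step whichever form the other place takes, but two pairs cannot show that this carries over to other cores or groups, and with both cyclohexyl steps within the scatter they do not establish that cyclohexyl lowers the number at all.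

The compounds shown leave open how a shorter chain such as propyl, or a phenyl ring, would read on the amide-type nitrogen. They also leave open whether fluoro or methoxy in place of methyl on the aromatic carbon would follow the step seen for chloro.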